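Working notes: trimming compound 3 to compound 4

A few compounds are considered here, and "the series" means these few. Any claim that something is new, unique, unknown or untested is made for them only; others in the source may bear on it.

Measured compounds and values in a functional assay on MIA PaCa-2 cells (Homo sapiens) for antiproliferative activity, read by MTT assay, with a stated time of 72 h; a higher number here means a weaker inhibitor, a lower number a stronger inhibitor:
- compound 1 `O=c1cc(CC(O)(COCc2ccccc2)COCc2ccccc2)[nH]c(=O)[nH]1`: > 100000 nM
- compound 2 `COc1cc(CC(COCc2ccccc2)COCc2ccccc2)nc(OC)n1`: "not determined" (no result reported)
- compound 3 `O=c1cc(CC(COCc2ccccc2)COCc2ccccc2)[nH]c(=O)[nH]1`: > 100000 nM

Compound 1 returns only an assay limit in this assay, > 100000 nM. Compound 3 also returns only a limit in this assay, > 100000 nM. For compound 2 the outcome in this assay is "not determined" (no result reported), so no number stands beside it. The one single-point step, a step that the two limits leave unreadable from compound 1 to compound 3, cannot be read in size because both ends sit at the limit; this is what the limit of > 100000 nM in this assay, at which 2 of the 3 values shown sit, records, with two of three shown values at that limit. Compound 3 therefore stands with no numeric value, only a limit, and no measured neighbour gives it a scale.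

Compound 4 `O=c1cc(CC(O)COCc2ccccc2)[nH]c(=O)[nH]1` differs from compound 3 by hydroxy in place of (benzyloxy)methyl on a saturated chain carbon bound to two saturated chain carbons. For the measured compounds named here, no measured step bears readably on this change; the only step available, from compound 1 to compound 3, is unreadable. With nothing in the series pulling away from the limit, compound 4 is expected to remain near it, so a step that the limit leaves unreadable from compound 3 to compound 4 is estimated as no movement beyond scatter. The estimate for compound 4 in this assay is 150000 nM, with a range from 30000 nM to 800000 nM, most likely reported again as a limit.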

Compound 4, half-maximal inhibitory concentration: > 100000 nM
Compound 4 ended at the assay's limit (the forecaster's own chance of this, stated with the estimate: 85%); the middle value is on the limit's open side.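

No new step can be read among compound 1, compound 3 and compound 4 in this assay, since each of the three returns only a limit: the limit of > 100000 nM in this assay, at which 3 of the 4 values shown sit.

The compounds shown leave open whether any change on the shared core gives a numeric value in this assay at all.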